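The source may report more compounds than this note shows. Statements on the series, on what has been measured and on what is new or still open speak of the compounds shown alone.

Measured so far:
- compound 1, `CC(C)Cc1ccc(C(C)c2nnc(COc3ccc(-c4ccccc4)cc3)o2)cc1`: 72.8%
- compound 2, `CCCCn1c(S)nnc1COc1ccc(-c2ccccc2)cc1`: 58.2%

In a functional assay on the whole organism (Tail, strain Swiss albino) for inhibition, with Mus musculus as the target, with a stated time of 4 h, at a dose of 10 mg/kg by the oral route (on this read-out lower numbers stand for less inhibition and higher numbers for more inhibition at the one dose given (going by the name of the read-out)), compound 1 gives 72.8%. In the same assay compound 2 gives 58.2%, the lower of the two values shown; the gap to compound 1 lies beyond the usual scatter of repeated measurements. The two compounds differ in more than one place, so the gap is not tied to any single change.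

Compound 3, `Fc1ccc(-n2c(S)nnc2COc2ccc(-c3ccccc3)cc2)cc1`, is the next one to be run. It differs from compound 2 in one place: 4-fluorophenyl in place of butyl on an aromatic nitrogen. The aromatic nitrogen that carried the butyl group now carries a 4-fluorophenyl group; the sulfanyl group and the large group on the ring stay as in compound 2.

For the measured compounds named here, no single-change pair shows what such a swap does in this assay, so the direction of the step is open. A small shift, not beyond the scatter, is the working expectation for the step of a number 4.8 percentage points higher from compound 2 to compound 3 (within the scatter). Compound 3 is therefore expected to give about 63% in this assay, most likely between 48% and 78%, with compound 2 at 58.2% as the anchor.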

Compound 3, a percentage reported as inhibition, in the whole organism at one dose (the size of the read-out at that dose, not a potency): 30.5%
Beside the measured number, compound 3's estimate is 32.5 percentage points above it; the whole stated range lies above it.
By their numbers in this assay, from the lowest: compound 3; then compound 2; then compound 1.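

In this assay, the aromatic nitrogen that bears the substituent is now shown not to be indifferent to what sits on it: 4-fluorophenyl in place of butyl gives a number 27.7 percentage points lower from compound 2 to compound 3 (beyond the scatter), the first single-change step in the series. The step lies beyond the scatter, so at this one dose, and with the sulfanyl group and the large group held fixed, butyl goes with clearly more inhibition than 4-fluorophenyl. No measurement at hand explains the size or direction of this step.

For the compounds shown here, the swap changes the chain to an aromatic ring and brings in fluorine at once, so the single step cannot show which part of the change goes with the lower inhibition. Open questions are how a phenyl group without fluorine, a benzyl group, or a shorter or longer alkyl chain such as propyl or hexyl would read on this nitrogen, and whether the step from butyl to 4-fluorophenyl would keep its direction and size with a methylthio group in place of the sulfanyl group.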